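The source may hold more compounds than are shown below. What is called first, only, known or untested is meant among the compounds shown, and "the series" means these compounds.

Measured compounds:
Compound 1 `O=[N+]([O-])c1c(CS(=O)(=O)c2ccccc2)nc2c(-c3cccc(F)c3)cc(Cl)cn12`: in an ADME assay on HepG2 cells (Homo sapiens) for cytotoxicity, read by MTT assay, with a stated time of 72 h (on this read-out lower numbers stand for higher toxicity in this test and higher numbers for lower toxicity in this test), compound 1 gives > 12500 nM, a limit of the assay.
Compound 2 `O=[N+]([O-])c1c(CS(=O)(=O)c2ccccc2)nc2c(-c3ccc(C(F)(F)F)cc3)cc(Cl)cn12`: in this assay compound 2 gives > 3900 nM, a limit of the assay.

Compound 2 therefore stands only at a limit, not at a number. Compound 1 likewise sits at a limit, (the limit of > 12500 nM in this assay, at which 1 of the 2 values shown sits), and compound 2 at the limit of > 3900 nM in this assay, at which 1 of the 2 values shown sits. Within the data shown here, the single available step, a step that the two limits leave unreadable from compound 1 to compound 2, gives no readable size. Compound 3 `O=[N+]([O-])c1c(CS(=O)(=O)c2ccccc2)nc2c(-c3ccco3)cc(Cl)cn12` differs from compound 2 by furan-2-yl in place of 4-(trifluoromethyl)phenyl on an aromatic carbon. Among the measured compounds shown here, with no step of readable size to draw on, no shift beyond the scatter is expected; the step from compound 2 to compound 3 is estimated as a step that the limit leaves unreadable from compound 2 to compound 3. Compound 3 is expected near 15000 nM, within 4000 nM to 60000 nM, most likely again reported only as a limit.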

Compound 3, half-maximal cytotoxic concentration: > 3900 nM
Compound 3 was reported as a limit (the forecaster's own chance of this, stated with the estimate: 70%); the middle value does not contradict the limit.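

Among these compounds, compound 1, compound 2 and compound 3 all stand at limits in this assay, so no step among them can be read. As far as these compounds go, whether 3-fluorophenyl, 4-(trifluoromethyl)phenyl or furan-2-yl on this aromatic carbon shifts the read-out in this assay remains open.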